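Bromo in Place of Methyl: What Compound 3 May Show

The source may report more compounds than this note shows. Statements on the series, on what has been measured and on what is new or still open speak of the compounds shown alone.

Compound 1 `CS(=O)(=O)c1cc(C(=O)N=C(N)N)ccc1C(F)(F)F`: 140 nM
Compound 2 `Cc1ccc(C(=O)N=C(N)N)cc1S(C)(=O)=O`: 210 nM

In a functional assay for inhibition of sodium/hydrogen exchanger (Oryctolagus cuniculus) (a lower number here means a stronger inhibitor, a higher number a weaker inhibitor), compound 1 gives 140 nM and compound 2 gives 210 nM. Compound 2 carries the larger of the two numbers, but the step of a 1.5-fold higher number from compound 1 to compound 2 (0.18 log units; within the scatter) lies within the scatter, so the two are not separated. Compound 3 `CS(=O)(=O)c1cc(C(=O)N=C(N)N)ccc1Br` differs from compound 2 by bromo in place of methyl on an aromatic carbon. Going by the values given here, the one measured step that bears on this change, a 1.5-fold higher number from compound 1 to compound 2 (0.18 log units; within the scatter), was small. The expected step is therefore a 1.2-fold lower number from compound 2 to compound 3 (0.09 log units; within the scatter), none beyond the scatter. Compound 3 is estimated at 170 nM, with a range from 80 nM to 400 nM.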

Compound 3, half-maximal inhibitory concentration: 180 nM
Compound 3: the middle estimate sits 1.1-fold (0.02 log units) below what was measured, and the stated range covers the measured number.
By their numbers in this assay, from the lowest: compounds 1, 3 and 2 (each within the scatter of the next).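

In this assay, the place ortho to a methylsulfonyl group now holds a third group, and bromo does not separate from either of the other two: the change gives a 1.2-fold lower number from compound 2 to compound 3 (0.07 log units; within the scatter), while the comparison with trifluoromethyl gives a 1.3-fold higher number from compound 1 to compound 3 (0.11 log units; within the scatter). Going by these compounds alone, the one earlier step showed this only for methyl and trifluoromethyl, whereas all three compounds now lie within the scatter of one another. Nothing available explains why these three groups read alike. Going by these compounds, whether an amine, a carboxylic acid or a longer chain at this place would give a step beyond the scatter stays open.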